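The source may hold more compounds than are shown below. What is called first, only, known or untested is meant among the compounds shown, and "the series" means these compounds.

Measured so far:
- compound 1 `O=S(=O)(c1cc(F)cc(F)c1)c1cnc2c(F)cccc2c1-c1cccc(Cl)c1`: 0.64 mL/min
- compound 2 `O=S(=O)(c1ccc(F)c(F)c1)c1cnc2c(F)cccc2c1-c1ccccc1F`: 1.39 mL/min

Two compounds have been run in an ADME assay on microsomes from liver (Homo sapiens) for metabolic stability, tested at 2.5 uM; on this read-out higher numbers stand for fast clearance and lower numbers for slow clearance. In this assay compound 1 gives 0.64 mL/min and compound 2 gives 1.39 mL/min. Within the data shown here, compound 2 therefore has the higher of the two numbers, and the only neighbour, compound 1, sits clearly lower, by a gap that is beyond the usual scatter. Among the measured compounds shown here, the two compounds differ from each other in more than one place, so no single step links them and their gap cannot be tied to one change.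

The next compound, compound 3 `O=S(=O)(c1ccc(F)c(F)c1)c1cnc2c(F)cccc2c1-c1cccc(Cl)c1`, is reached from compound 2 by a single change: 3-chlorophenyl in place of 2-fluorophenyl on an aromatic carbon. Compound 3 thus shares the 3-chlorophenyl of compound 1 while keeping the rest of compound 2.

For the measured compounds named here, with no matching step on record, the expectation rests only on the two measured values. Compound 3 is expected to land between them, so the estimated step of a 1.5-fold lower number from compound 2 to compound 3 (0.19 log units; within the scatter) points modestly downward, possibly within the scatter. For compound 3 the estimate in this assay is 0.9 mL/min, with a plausible range from 0.4 mL/min to 2 mL/min.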

Compound 3, intrinsic clearance in a liver preparation (reported as CLH), per the amount of preparation that the assay uses: 1.13 mL/min
Compound 3: the middle estimate sits 1.3-fold (0.10 log units) below what was measured; measured number inside the range.
By their numbers in this assay, from the lowest: compounds 1, 3 and 2 (each within the scatter of the next, the first and the last beyond it).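

In this assay, 3-chlorophenyl in place of 2-fluorophenyl on the aromatic carbon opposite the ring nitrogen gives a 1.2-fold lower number from compound 2 to compound 3 (0.09 log units; within the scatter), so this swap cannot be told apart from the ordinary spread of repeated measurements. Compound 3 also gives the first one-place link to compound 1: 3,4-difluorophenyl in place of 3,5-difluorophenyl on the sulfonyl sulfur gives a 1.8-fold higher number from compound 1 to compound 3 (0.25 log units; within the scatter), which is again no clear difference. Each of these two single changes, read alone, is therefore too small to count as a real shift in clearance, at either of the two places on the molecule.

No other measurement here speaks to what lies behind these two steps. On these data alone, the first swap alters both the halogen and its place on the phenyl ring, so 3-fluorophenyl or 2-chlorophenyl would be needed to separate those two changes, and it remains open whether a plain phenyl or a methoxyphenyl at the same carbon would move the clearance beyond the scatter.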